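The compounds below may be only part of what the source reports. "The series", "measured", "known", "first", "only" and "open" are said of these compounds alone.

Of the compounds shown here, three of the shared core have been measured in a functional assay (blood) for inhibition, with Homo sapiens as the target; a lower number here means a stronger inhibitor, a higher number a weaker inhibitor. Compound 1 `COC1(c2cc(F)cc(Sc3ccc4c(c3)CC/C4=N\OCC#N)c2)CCOCC1` gives 30 nM, compound 3 `CO[C@]1(c2cc(F)cc(S(=O)(=O)c3ccc(/C(C)=N/OCC#N)cc3)c2)CCO[C@@H](C)C1` gives 60 nM, and compound 2 `C/C(=N\OCCSc1nnnn1C)c1ccc(Sc2cc(F)cc(C3CCOCC3)c2)cc1` gives 120 nM, the highest of the three numbers; its gap to compound 3 lies within the usual scatter, while its gap to compound 1 lies beyond it. Compound 4 `C/C(=N\OC(=O)C(C)(C)C)c1ccc(Sc2cc(F)cc(C3CCOCC3)c2)cc1` differs from compound 2 in one place: (tert-butyl)carbonyl in place of 2-((1-methyl-1H-tetrazol-5-yl)sulfanyl)ethyl on an oxygen. For the measured compounds named here, no measured pair shows this exact change, so the expectation rests on the spread already seen. The step from compound 2 to compound 4 is expected to be small, a 1.3-fold higher number from compound 2 to compound 4 (0.10 log units; within the scatter), with no direction beyond the scatter clearly favoured. Compound 4 is therefore estimated at 150 nM, between 50 nM and 500 nM.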

Compound 4, half-maximal inhibitory concentration: 40 nM
Compound 4: the middle estimate sits 3.8-fold (0.57 log units) above what was measured; the whole stated range lies above it.
By their numbers in this assay, from the lowest: compounds 1, 4, 3 and 2 (each within the scatter of the next, the first and the last beyond it).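

For the compounds shown here, this is the first pair here that differs in one place, so the group on the oxygen can be judged on its own. In this assay, (tert-butyl)carbonyl in place of 2-((1-methyl-1H-tetrazol-5-yl)sulfanyl)ethyl gives a 3.0-fold lower number from compound 2 to compound 4 (0.48 log units; beyond the scatter), showing that this position accepts a group with no ring and that the tetrazole is not required for inhibition. No measurement given here explains the shift.

Still open, on these data alone, is whether the carbonyl or the tert-butyl carries this step; an acetyl or a plain ethyl group on this oxygen would separate the two. As far as these compounds go, whether the step holds on the other cores also remains open.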